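Ether side chains on the shared core: working notes

This account rests on a few compounds, and the source may have more. Where it says the series, first, only, none or still open, it means among the compounds named here.

- compound 1 `CC(C)=CC[C@@H](OC(=O)c1ccco1)C1=CC(=O)c2c(O)ccc(O)c2C1=O`: > 100000 nM (a limit)
- compound 2 `COC(C)CO[C@H](CC=C(C)C)C1=CC(=O)c2c(O)ccc(O)c2C1=O`: 16600 nM
- compound 3 `COCCO[C@H](CC=C(C)C)C1=CC(=O)c2c(O)ccc(O)c2C1=O`: 43200 nM
- compound 4 `CCC(O)CO[C@H](CC=C(C)C)C1=CC(=O)c2c(O)ccc(O)c2C1=O`: not yet measured

All values come from a functional assay on DU-145 cells (Homo sapiens) for cytotoxicity, read by MTT assay; a lower number here means a stronger inhibitor, a higher number a weaker inhibitor. Of the two actual numbers, compound 3 holds the higher, at 43200 nM. Compound 4 differs from compound 3 by 1-hydroxypropyl in place of methoxymethyl on a saturated chain carbon bound to an oxygen on a saturated carbon, on a saturated chain carbon bound to an oxygen on a saturated carbon. The closest measured change is a 2.6-fold higher number from compound 2 to compound 3 (0.42 log units; beyond the scatter), where compound 2 loses a methyl from its side chain. The steps of an at least 6.0-fold lower number from compound 1 to compound 2 (0.77 log units; beyond the scatter) and an at least 2.3-fold lower number from compound 1 to compound 3 (0.36 log units; beyond the scatter) replace the ester and bear less. Going by the values given here, no measured compound shows the effect of the free hydroxyl. A modest fall is expected in this assay: a 2.0-fold lower number from compound 3 to compound 4 (0.29 log units; within the scatter). Compound 4 is estimated at 22000 nM, with an expected range of 8000 nM to 60000 nM.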

Compound 4, half-maximal inhibitory concentration: 16400 nM
Beside the measured number, compound 4's estimate is 1.3-fold (0.13 log units) above it; the measured number falls inside the stated range.
By their numbers in this assay, from the lowest: compounds 4 and 2 (each within the scatter of the next); then compound 3. At a limit, above all of these: compound 1.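

In this assay, the swap to 1-hydroxypropyl on this saturated chain carbon gives a 2.6-fold lower number from compound 3 to compound 4 (0.42 log units; beyond the scatter), the first measured step involving a free hydroxyl. The swap from 1-methoxyethyl gives a 1.0-fold lower number from compound 2 to compound 4 (0.01 log units; within the scatter), so the hydroxyl and the methoxy chain are not separated here. The step of an at least 6.0-fold lower number from compound 1 to compound 4 (0.78 log units; beyond the scatter) starts from a limit.

The step from compound 3 changes both the hydroxyl and the chain, and the compounds shown do not tell the two apart. From the compounds shown here alone, what an amine or a carboxylic acid in place of the hydroxyl, or a longer chain, would give also stays open.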